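A few compounds are considered here, and "the series" means these few. Any claim that something is new, unique, unknown or untested is made for them only; others in the source may bear on it.

Measured so far:
- compound 1 `COc1cc(-c2nn(-c3cccc(NC(=O)Nc4ccc(Cl)c(Cl)c4)c3)cc2-c2ccncc2)ccc1Cl` — in a functional assay on KM12 cells (Homo sapiens) for inhibition, read by sulforhodamine B assay, with a stated time of 48 h (a lower number here means a stronger inhibitor of growth, a higher number a weaker inhibitor of growth), compound 1 gives 811 nM
- compound 2 `COc1cc(-c2nn(-c3cccc(NC(=O)c4ccc(Cl)c(C(F)(F)F)c4)c3)cc2-c2ccncc2)ccc1Cl` — in this assay compound 2 gives 2060 nM

Compound 2 stands at the higher, weaker end of these two numbers: going a 2.5-fold higher number from compound 1 to compound 2 (0.40 log units; beyond the scatter). That single measured step is the only one available, and it changes two things at once, the ring that carries the halogens and the link to the carbonyl carbon.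

Compound 3 `COc1cc(-c2nn(-c3cccc(NC(=O)Nc4ccc(Cl)c(C(F)(F)F)c4)c3)cc2-c2ccncc2)ccc1Cl` has not yet been measured. It differs from compound 2 in one place: (4-chloro-3-(trifluoromethyl)phenyl)amino in place of 4-chloro-3-(trifluoromethyl)phenyl on a carbonyl carbon. This puts back the amino link seen in compound 1 while keeping the ring of compound 2, so compound 3 shares one feature with each measured compound.

The step from compound 1 to compound 2 bears on this change only in part, since one of the two things it changed is reversed here while the other is kept. The expectation is a modest move in this assay back toward compound 1, that is a lower number for compound 3, estimated as a 2.6-fold lower number from compound 2 to compound 3 (0.41 log units; beyond the scatter). Compound 3 is therefore expected to give about 800 nM, with a range from 250 nM to 2500 nM.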

Compound 3, concentration for 50% growth inhibition: 1060 nM
Compound 3: middle estimate off by 1.3-fold (0.12 log units), on the low side; the range from low to high includes it.
By their numbers in this assay, from the lowest: compounds 1, 3 and 2 (each within the scatter of the next, the first and the last beyond it).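

In this assay, restoring the amino link on the carbonyl carbon gives a 1.9-fold lower number from compound 2 to compound 3 (0.29 log units; within the scatter), while trifluoromethyl in place of chloro on an aromatic carbon gives a 1.3-fold higher number from compound 1 to compound 3 (0.12 log units; within the scatter); both steps lie within the usual scatter, so compound 3 cannot be told apart from compound 1 or from compound 2. The earlier gap, a 2.5-fold higher number from compound 1 to compound 2 (0.40 log units; beyond the scatter), can now be seen as two single changes, neither of which can be read with confidence on its own, and only the two together pass beyond the scatter. Nothing measured here accounts for these numbers in terms of what either group does.

The compounds shown leave open whether a fluoro or methyl group on that aromatic carbon, in place of chloro or trifluoromethyl, would shift the number beyond the scatter. They also leave open what a sulfonyl group in place of the carbonyl, or a methylene in place of the amino link, would do to growth inhibition in these cells.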